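Swapping the ring methyl for methylsulfonyl on a shared core

A few compounds are considered here, and "the series" means these few. Any claim that something is new, unique, unknown or untested is made for them only; others in the source may bear on it.

Of the compounds shown here, three on a shared core have been measured in an assay on HEK293 cells for agonist activity at Toll-like receptor 8 (Homo sapiens), read by a luciferase reporter, with a stated time of 6 h; a higher number here means that more compound is needed for the effect, a lower number that less compound is needed. Compound 1 `CCCCNc1nc(N)nc2c1CN(C)CC2`, which carries a methyl on the ring nitrogen, gives 0.03 uM in this assay, the lowest of the three numbers, and its distance to each of the other two lies beyond the scatter. Compound 2 `CCCCNc1nc(N)nc2c1CCN(C(C)=O)C2` gives 0.4 uM, and compound 3 `CCCCNc1nc(N)nc2c1CCN(C(=O)c1ccccc1)C2` gives 0.8 uM. Among the compounds with values here, the only pair that differs in a single place is compound 2 and compound 3: a 2.0-fold higher number from compound 2 to compound 3 (0.30 log units; within the scatter).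

Compound 4 `CCCCNc1nc(N)nc2c1CN(S(C)(=O)=O)CC2` has not yet been measured. It differs from compound 1 by methylsulfonyl in place of methyl on an amine nitrogen in a ring.

Within the data shown here, no measured step matches this exact change. The step from compound 2 to compound 3 concerns a carbonyl substituent and stays within the scatter, so it says little here. The values of compound 2 and compound 3, both carrying a carbonyl group rather than a methyl on the ring nitrogen, are markedly higher than that of compound 1, although those compounds also differ from compound 1 elsewhere. On that basis, replacing the methyl with a larger, acceptor-bearing group is expected to raise the number: a 10-fold higher number from compound 1 to compound 4 (1.00 log units; beyond the scatter). Compound 4 is therefore estimated at 0.3 uM, within a range from 0.08 uM to 1.2 uM.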

Compound 4, minimum effective concentration: 9.9 uM
The estimate for compound 4 lay 33-fold (1.52 log units) below the measured number; measured number above the stated range.
By their numbers in this assay, from the lowest: compound 1; then compounds 2 and 3 (each within the scatter of the next); then compound 4.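

The ring nitrogen of the shared core proves to be a very sensitive place in this assay: methylsulfonyl in place of methyl on this amine nitrogen in a ring gives a 330-fold higher number from compound 1 to compound 4 (2.52 log units; beyond the scatter), a large step from one change. Within the data shown here, it is the first step measured at this position, as the only earlier single-place pair changed a group on a carbonyl carbon and stayed within the scatter. No measurement at hand accounts for a rise of this size.

With only methyl and methylsulfonyl shown on this nitrogen of the core of compound 1, it stays open whether any group larger than methyl raises the number or whether the sulfonyl is what matters. A plain hydrogen, an ethyl group or a longer carbon chain at this place would help to separate those two readings.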